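This account rests on a few compounds, and the source may have more. Where it says the series, first, only, none or still open, it means among the compounds named here.

Measured in a functional assay on cells (Cancer cell lines, Homo sapiens) for cytotoxicity, read by sulforhodamine B assay, with a stated time of 48 h; a lower number here means a stronger inhibitor of growth, a higher number a weaker inhibitor of growth: compound 1 `NS(=O)(=O)c1ccc(-n2nc(-c3ccc(Cl)cc3)cc2-c2cc(O)ccc2O)cc1` gives 35500 nM; compound 2 `CC(=O)NS(=O)(=O)c1ccc(-n2nc(-c3ccccc3)cc2-c2cc(O)ccc2O)cc1` gives 100000 nM; compound 3 `NS(=O)(=O)c1ccc(-n2nc(-c3ccc(Cl)cc3)cc2C2=CC(=O)C=CC2=O)cc1` gives 53000 nM.

Compound 3 differs from compound 1 by a group of 8 heavy atoms (6 carbon, 2 oxygen; one six-membered non-aromatic ring of carbon only) in place of a group of 8 heavy atoms (6 carbon, 2 oxygen; one six-membered aromatic ring of carbon only), on an aromatic carbon, and the step of a 1.5-fold higher number from compound 1 to compound 3 (0.17 log units; within the scatter) is within the scatter. How the core of compound 2 differs from that of compound 1 is not broken down here. Compound 4 `CC(=O)NS(=O)(=O)c1ccc(-n2nc(-c3ccccc3)cc2C2=CC(=O)C=CC2=O)cc1` differs from compound 2 by a group of 8 heavy atoms (6 carbon, 2 oxygen; one six-membered non-aromatic ring of carbon only) in place of a group of 8 heavy atoms (6 carbon, 2 oxygen; one six-membered aromatic ring of carbon only), on an aromatic carbon. This is the same kind of change as from compound 1 to compound 3, though the surroundings differ: there the ring atom bears a 4-sulfamoylphenyl group and the other ring atom a 4-chlorophenyl group, here a large group and a phenyl group. Since the earlier step of a 1.5-fold higher number from compound 1 to compound 3 (0.17 log units; within the scatter) was small, compound 4 is expected to show a step of about a 1.2-fold higher number from compound 2 to compound 4 (0.08 log units; within the scatter). In this assay compound 4 is therefore estimated at 120000 nM, between 50000 nM and 300000 nM.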

Compound 4, concentration for total growth inhibition: 100000 nM
The estimate for compound 4 lay 1.2-fold (0.08 log units) above the measured number; low and high end bracket the measured number.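

In this assay, replacing the 2,5-dihydroxyphenyl group with the non-aromatic six-membered ring gives no change at the digits printed from compound 2 to compound 4 (within the scatter). Set beside the earlier case, the change carries from one core to the other with no gap beyond the scatter: the same change on two cores in this assay, a 1.5-fold higher number (0.17 log units; within the scatter) from compound 1 to compound 3 and no change at the digits printed (within the scatter) from compound 2 to compound 4, 1.5-fold (0.17 log units) apart, within the scatter of two such steps This rests on only two pairs, so it shows that the change behaved alike on these two cores but does not show that it would do so on any other core.

The compounds shown leave open how a phenyl ring bearing an amine or a carboxylic acid would read in place of these two groups. They also leave open whether a longer chain in place of the acetyl group would alter the result.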